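Replacing the oct-1-yn-1-yl arm of compound 2

The source may report more compounds than this note shows. Statements on the series, on what has been measured and on what is new or still open speak of the compounds shown alone.

Values in a functional assay on NIH3T3 cells (Mus musculus); on this read-out higher numbers stand for an effect only at larger amounts of compound and lower numbers for an effect already at smaller amounts:
- Compound 1 `Cn1cncc1C(OCc1ccc(C#N)cc1C#Cc1ccc(C#N)cc1)c1ccc(C#N)cc1`: 11.6 nM
- Compound 2 `CCCCCCC#Cc1cc(C#N)ccc1COC(c1ccc(C#N)cc1)c1cncn1C`: > 0.1 nM (a limit, not a number)

Compound 2 stands only at a limit, > 0.1 nM. Within the data shown here, the one measured step, a step that the limit leaves unreadable from compound 1 to compound 2, therefore gives no usable size or direction. Compound 3 `Cn1cncc1C(OCc1ccc(C#N)cc1/C=C/c1ccc([N+](=O)[O-])cc1)c1ccc(C#N)cc1` carries 2-(4-nitrophenyl)ethenyl in place of oct-1-yn-1-yl on an aromatic carbon. The expectation leans instead on compound 1 at 11.6 nM, whose arm also holds a six-membered aromatic ring of carbon only. The step expected in this assay is a step that the limit leaves unreadable from compound 2 to compound 3. Compound 3 is estimated at 15 nM, with an expected range of 2 nM to 100 nM.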

Compound 3, half-maximal effective concentration: 2.24 nM
Compound 3: the middle estimate sits 6.7-fold (0.83 log units) above what was measured, and the stated range covers the measured number.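

In this assay, placing 2-(4-nitrophenyl)ethenyl in place of 2-(4-cyanophenyl)ethynyl on this aromatic carbon gives a 5.2-fold lower number from compound 1 to compound 3 (0.71 log units; beyond the scatter). Among these compounds, this is the first readable change at this position, and it shows that the value responds to the make-up of an arm holding an aromatic ring. The step involving compound 2 cannot be read, because that compound has only a limit: the limit of > 0.1 nM in this assay, at which 1 of the 3 values shown sits.

The double bond and the nitro group change together, leaving their separate shares open. Going by these compounds, how an arm holding an amine or a carboxylic acid would read also remains open.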